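Side-chain swap at the amide-bearing carbon, tail flick read-out

The source may report more compounds than this note shows. Statements on the series, on what has been measured and on what is new or still open speak of the compounds shown alone.

Compound 1 `N=C(N)NCCC[C@H](NC(=O)CN(c1ncnc2c1ncn2C1CCCCO1)C1CC1)C(=O)OCc1ccccc1` and compound 2 `CC(C)[C@H](NC(=O)CN(c1nc(Cl)nc2[nH]cnc12)C1CC1)C(=O)O` have both been run in a functional assay on the whole organism (Tail, strain ICR) with Mus musculus as the target, in the tail flick test, with a stated time of 30 min, at a dose of 25 umol/kg by the oral route; on this read-out lower numbers stand for a weaker effect and higher numbers for a stronger effect at the one dose given. In this assay compound 1 gives 34.3%, while compound 2 gives 31.2%. Of the two numbers, that of compound 1 is the larger, yet the margin lies within the scatter, so the two cannot be told apart. Compound 1 and compound 2 differ in several places at once, so no single step can be read between them.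

Compound 3 `C[C@@H](O)[C@H](NC(=O)CN(c1ncnc2c1ncn2C1CCCCO1)C1CC1)C(=O)OCc1ccccc1` is not yet measured. Against compound 1 it carries a group of 3 heavy atoms (2 carbon, 1 oxygen; no ring) in place of a group of 7 heavy atoms (4 carbon, 3 nitrogen; no ring), on a saturated chain carbon bound to an amide-type nitrogen and a carbonyl carbon. For the measured compounds named here, no measured pair in this assay shows this change, so no step size is known for it. A modest drop, at the edge of the scatter or a little beyond it, is expected. The step from compound 1 to compound 3 is estimated at a number 9.3 percentage points lower from compound 1 to compound 3 (within the scatter). Compound 3 is expected to give 25% in this assay, within 10% to 42%.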

Compound 3, a percentage reported as activity, at one dose (the size of the read-out at that dose, not a potency): 23.6%
The estimate for compound 3 lay 1.4 percentage points above the measured number; the measured number falls inside the stated range.
By their numbers in this assay, from the lowest: compounds 3, 2 and 1 (each within the scatter of the next, the first and the last beyond it).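

At the saturated chain carbon bound to an amide-type nitrogen and a carbonyl carbon, the side chain does register in this assay: replacing the group of 7 heavy atoms with 1-hydroxyethyl appears as a number 10.7 percentage points lower from compound 1 to compound 3 (beyond the scatter). For the compounds shown here, this is the first single-place step, and it is modest, so this position affects the read-out without the effect being lost when the group is replaced. No measurement available here bears on why the read-out moves with this change.

The swap alters heavy-atom count and hydrogen-bond donor count together (3 donors leaving, 1 entering), and the shown compounds do not separate the two. On these data alone, whether a longer chain ending in an amine or a carboxylic acid would keep the read-out of compound 1 remains open.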